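The source may report more compounds than this note shows. Statements on the series, on what has been measured and on what is new or still open speak of the compounds shown alone.

In an ADME assay on Huh-7 cells (Homo sapiens) for cytotoxicity (on this read-out higher numbers stand for lower toxicity in this test and lower numbers for higher toxicity in this test), compound 1 `C[C@@]1(O)[C@H](O)[C@@H](CO)O[C@H]1n1cnc2c(Cl)nc(N)nc21` gives > 100000 nM, which is a limit of the assay and not a number. Compound 2 `COCCCOc1nc(N)nc2c1ncn2[C@@H]1O[C@H](CO)[C@@H](O)[C@@]1(C)O` gives > 100000 nM, and this too is only a limit. Within the data shown here, the one measured change that bears on what follows is a step that the two limits leave unreadable from compound 1 to compound 2, so it offers no size to carry forward. Compound 3 `CC(C)Oc1nc(N)nc2c1ncn2[C@@H]1O[C@H](CO)[C@@H](O)[C@@]1(C)O` alters the chain of compound 2: isopropyl in place of 3-methoxypropyl on an oxygen on an aromatic ring, which puts isopropyl in place of 3-methoxypropyl on an oxygen on an aromatic ring. Compound 1 and compound 2 both rest at the limit of > 100000 nM in this assay, at which 2 of the 2 values shown sit, so no step beyond the usual scatter is expected in this assay, in either direction. The estimated change is a number no higher from compound 2 to compound 3 (the limit leaves the size open). Compound 3 is expected to read about 100000 nM, with an estimated range from 50000 nM to 200000 nM, and may well be reported only as a limit.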

Compound 3, half-maximal cytotoxic concentration: > 100000 nM
Compound 3: only a limit was reported; the forecaster's own chance of this, stated with the estimate: 85%; the middle value sits exactly at the limit.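

No step between compound 1, compound 2 and compound 3 can be read in this assay, since each result is only a limit: the limit of > 100000 nM in this assay, at which 3 of the 3 values shown sit.

The compounds shown leave open whether swapping chloro, 3-methoxypropoxy and isopropoxy changes toxicity in this assay at all.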